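Moving the Carboxyl Group Around the Outer Ring

A few compounds are considered here, and "the series" means these few. Any claim that something is new, unique, unknown or untested is made for them only; others in the source may bear on it.

Measured compounds in a functional assay on HEK293 cells for agonist activity at Bile acid receptor (Homo sapiens), read by a luciferase reporter; on this read-out higher numbers stand for larger maximal responses and lower numbers for smaller maximal responses:
Compound 1, `CN(Cc1cccc(C(=O)O)c1)c1ccc(OCc2c(-c3c(Cl)cccc3Cl)noc2C2CC2)nc1C(F)(F)F`, gives 43%.
Compound 2, `O=C(O)c1ccccc1OCc1ccc(OCc2c(-c3c(Cl)cccc3Cl)noc2C2CC2)nc1C(F)(F)F`, gives 33%.

Compound 2 stands lowest of the two numbers, but its nearest neighbour, compound 1, lies within the scatter, so the two cannot be told apart: a number 10 percentage points lower from compound 1 to compound 2 (within the scatter). Compound 3, `O=C(O)c1ccc(OCc2ccc(OCc3c(-c4c(Cl)cccc4Cl)noc3C3CC3)nc2C(F)(F)F)cc1`, has not been measured. It differs from compound 2 in one place: 4-carboxyphenyl in place of 2-carboxyphenyl on an oxygen on a saturated carbon. Within the data shown here, no measured step moves a carboxyl group around a ring; the only known step swaps the whole linker and ring together, and that step stayed within the scatter. Among the measured compounds shown here, with no step of the same kind available, nothing points to a large shift in this assay in either direction, so a step within the scatter is expected: a number 5 percentage points higher from compound 2 to compound 3 (within the scatter). Compound 3 is therefore estimated at 38%, with a wide range from 15% to 65% because of the missing precedent.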

Compound 3, largest response reached (reported as efficacy), in percent of the reference or control that the assay uses: 42%
The estimate for compound 3 lay 4 percentage points below the measured number; the range from low to high includes it.
By their numbers in this assay, from the lowest: compounds 2, 3 and 1 (each within the scatter of the next).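

Placing the carboxyl group as 4-carboxyphenyl instead of 2-carboxyphenyl on the oxygen is the first direct test of where this group sits on the outer ring, and in this assay the two placements cannot be told apart (a number 9 percentage points higher from compound 2 to compound 3 (within the scatter)). The comparison of the two linkers, now with the carboxyl group as (4-carboxyphenoxy)methyl, likewise stays within the scatter (a number 1 percentage points lower from compound 1 to compound 3 (within the scatter)), so neither change separates these compounds on this read-out. Nothing available explains these numbers.

As far as these compounds go, it remains open whether an amide or a nitrile in place of the carboxylic acid would give a number beyond the scatter. Also open, from the compounds shown here alone, is whether a longer chain between the oxygen and the outer ring would separate compounds that these three changes leave together.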